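The source may report more compounds than this note shows. Statements on the series, on what has been measured and on what is new or still open speak of the compounds shown alone.

Three compounds have been measured in a functional assay on HEK293 cells for positive allosteric modulation of metabotropic glutamate receptor 5 (Rattus norvegicus), read by fluorescence and calcium flux; on this read-out higher numbers stand for larger maximal responses and lower numbers for smaller maximal responses:
compound 1, `C[C@@H](NC(=O)c1ccc(C#Cc2ccc(F)cc2)cn1)C(C)(C)O`, gives 66.2%;
compound 2, `C[C@@H](NC(=O)c1ccc(C#Cc2cccc(F)c2)nn1)C(C)(C)O`, gives 70.2%;
compound 3, `CC(C)[C@@H](C)NC(=O)c1ccc(C#Cc2cccc(F)c2)cn1`, gives 69.3%.

Compound 3 stands second highest of these three numbers, yet its gap to compound 2 and its gap to compound 1 both fall within the usual scatter, so the three readings cannot be told apart. Compound 4, `CC(C)(O)CNC(=O)c1ccc(C#Cc2cccc(F)c2)cn1`, differs from compound 3 in one place: 2-hydroxy-2-methylpropyl in place of 1,2-dimethylpropyl on an amide-type nitrogen. For the measured compounds named here, no two measured compounds differ in a single place, so there is no measured step to lean on. The expected step, a number 3.3 percentage points lower from compound 3 to compound 4 (within the scatter), is small and in neither direction beyond the scatter. Compound 4 is estimated to give 66%, between 50% and 82%.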

Compound 4, largest response reached (reported as efficacy), in percent of the reference or control that the assay uses: 61.5%
Compound 4: middle estimate off by 4.5 percentage points, on the high side; the range from low to high includes it.
By their numbers in this assay, from the lowest: compounds 4, 1, 3 and 2 (each within the scatter of the next).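

For the compounds shown here, on this assay the change from 1,2-dimethylpropyl to 2-hydroxy-2-methylpropyl on the amide-type nitrogen gives a number 7.8 percentage points lower from compound 3 to compound 4 (within the scatter) and is the first single-place comparison here. Adding one hydrogen-bond donor and one acceptor at this position and losing the defined stereocentre thus leaves the maximal response indistinguishable, at least in this one pair. No measurement at hand speaks to why the response holds. Open, on these data alone, is how an amine or a carboxylic acid on this chain would read, and whether a longer chain would shift the response beyond the scatter.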